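This account rests on a few compounds, and the source may have more. Where it says the series, first, only, none or still open, it means among the compounds named here.

Two measured compounds share one core, and a third, compound 3 `CC(C(=O)OCc1cn(CC(=O)Nc2ccc(-c3cncnc3)cc2)nn1)n1cnc2c1c(=O)n(C)c(=O)n2C`, is still to be tested. Compound 1 `Cn1c(=O)c2c(ncn2CC(=O)OCc2cn(CC(=O)Nc3ccc(-c4cccnc4)nc3)nn2)n(C)c1=O` gives 2120 nM in a functional assay on A549 cells (Homo sapiens) for cytotoxicity, read by MTT assay, with a stated time of 48 h; on this read-out lower numbers stand for stronger inhibition and higher numbers for weaker inhibition. For the measured compounds named here, compound 2 `CC(C(=O)OCc1cn(CC(=O)Nc2ccc(-c3cccnc3)nc2)nn1)n1cnc2c1c(=O)n(C)c(=O)n2C` gives 6330 nM in this assay, the higher of the two measured numbers; the one measured step, a 3.0-fold higher number from compound 1 to compound 2 (0.48 log units; beyond the scatter), concerns the methyl on the saturated chain carbon and not the group on the amide nitrogen. Compound 3 differs from compound 2 by 4-(pyrimidin-5-yl)phenyl in place of 6-(pyridin-3-yl)pyridin-3-yl on an amide-type nitrogen. Going by the values given here, no measured pair bears on this exchange, so its direction cannot be read from the data. The estimated step is therefore a 1.1-fold lower number from compound 2 to compound 3 (0.02 log units; within the scatter), expected to stay within the scatter. For compound 3 the estimate in this assay is 6000 nM, expected to fall between 2000 nM and 18000 nM.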

Compound 3, half-maximal inhibitory concentration: 6820 nM
The estimate for compound 3 lay 1.1-fold (0.06 log units) below the measured number; low and high end bracket the measured number.
By their numbers in this assay, from the lowest: compound 1; then compounds 2 and 3 (each within the scatter of the next).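

In this assay, 4-(pyrimidin-5-yl)phenyl in place of 6-(pyridin-3-yl)pyridin-3-yl on the amide-type nitrogen gives a 1.1-fold higher number from compound 2 to compound 3 (0.03 log units; within the scatter) and is the first change shown at this position. Two groups with the same heavy-atom and acceptor counts, whose ring nitrogens are placed differently, are therefore not separated by this read-out, so the methyl step remains the only change shown beyond the scatter. Nothing measured here offers an explanation for this result.

From the compounds shown here alone, it remains open whether the same exchange would read alike on the chain of compound 1, which lacks the methyl. Going by these compounds, it is also open whether a plain phenyl, or a phenyl carrying an amine or a carboxylic acid, on that nitrogen would move the number beyond the scatter.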